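This account rests on a few compounds, and the source may have more. Where it says the series, first, only, none or still open, it means among the compounds named here.

The measured compounds:
compound 1 `CN1CCN(CCNCc2cn(-c3ccc([N+](=O)[O-])cc3)nc2-c2ccc(OC(F)(F)F)cc2)CC1`: 4400 nM
compound 2 `COc1ccc(-n2cc(CNCCN3CCN(C)CC3)c(-c3ccccc3C)n2)cc1`: > 20000 nM
compound 3 `Cc1c(CNCCN2CCN(C)CC2)c(-c2ccccc2)nn1-c1ccc(F)cc1`: > 20000 nM

Three compounds sharing one core were tested in an ADME assay on Huh-7 cells (Homo sapiens) for cytotoxicity; on this read-out lower numbers stand for higher toxicity in this test and higher numbers for lower toxicity in this test. Compound 1 gives a number, 4400 nM. Compound 2 gives only > 20000 nM, which is a limit of the assay rather than a number. Compound 3 likewise gives > 20000 nM, again a limit. Compound 2 and compound 3 thus both sit at the limit of > 20000 nM in this assay, at which 2 of the 3 values shown sit, and the number for compound 1 stands apart from them. Among the measured compounds shown here, no pair of the measured compounds differs in a single place, so no measured step is available.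

Compound 4 `Cc1ccccc1-c1nn(-c2ccc(C(F)(F)F)cc2)cc1CNCCN1CCN(C)CC1` is the next compound. It differs from compound 2 in one place: trifluoromethyl in place of methoxy on an aromatic carbon. For the measured compounds named here, with no measured step to lean on, the expectation for compound 4 rests on compound 2 sitting at its limit and is a number no higher from compound 2 to compound 4 (the limit leaves the size open), no change beyond the scatter. Compound 4 is therefore estimated at 20000 nM, within 7000 nM to 50000 nM.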

Compound 4, half-maximal cytotoxic concentration: 11000 nM
Beside the measured number, compound 4's estimate is 1.8-fold (0.26 log units) above it, within the range that was stated.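

Among the compounds shown here, at this position, para to a large group, the change from 4-methoxyphenyl to 4-(trifluoromethyl)phenyl gives the first step in this assay that can be read, and compound 4 gives 11000 nM, a number rather than a limit. The step is an at least 1.8-fold lower number from compound 2 to compound 4 (0.25 log units; that floor lies within the scatter), so the data do not establish a real shift in this read-out from this change. Its true size stays open because compound 2 gives only a limit: the limit of > 20000 nM in this assay, at which 2 of the 4 values shown sit.

The compounds shown leave open what a nitrile or a carboxylic acid on this aromatic carbon would give in this assay. They also leave open whether trifluoromethyl in place of methoxy would give a step of similar size on a different substitution pattern of the shared core.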